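A few compounds are considered here, and "the series" means these few. Any claim that something is new, unique, unknown or untested is made for them only; others in the source may bear on it.

Compound 1 `O=C(COCc1ccccc1)N1CCN(c2ccc(Cl)cc2Cl)CC1`: 450 mL.min-1.g-1
Compound 2 `O=C(COCc1cnccn1)N1CCN(c2ccc(Cl)cc2Cl)CC1`: 4 mL.min-1.g-1

In an in vitro ADME assay on microsomes from liver (Homo sapiens) for metabolic stability (on this read-out lower numbers stand for slow clearance and higher numbers for fast clearance), compound 2 gives 4 mL.min-1.g-1, the lowest of the two numbers, while compound 1 gives 450 mL.min-1.g-1. Compound 3 `O=C(COCc1cscn1)N1CCN(c2ccc(Cl)cc2Cl)CC1` differs from compound 2 by 1,3-thiazol-4-yl in place of pyrazin-2-yl on a saturated chain carbon bound to an oxygen on a saturated carbon. Among the measured compounds shown here, the one measured step at this place, a 110-fold lower number from compound 1 to compound 2 (2.05 log units; beyond the scatter), also exchanged one aromatic ring for another there, and it was large. A second ring exchange at the same place may move the number again, and with compound 2 at the low end a moderate rise is expected, a 3.8-fold higher number from compound 2 to compound 3 (0.57 log units; beyond the scatter). Compound 3 is therefore estimated at 15 mL.min-1.g-1, within 4 mL.min-1.g-1 to 60 mL.min-1.g-1.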

Compound 3, intrinsic clearance in microsomes: 62 mL.min-1.g-1
For compound 3 the middle estimate is 4.1-fold (0.62 log units) below the measured one; the measured number lies above the stated range.
By their numbers in this assay, from the lowest: compound 2; then compound 3; then compound 1.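

In this assay, the ring at this place matters well beyond a simple choice between phenyl and a ring with hetero atoms: a 16-fold higher number from compound 2 to compound 3 (1.19 log units; beyond the scatter), although pyrazin-2-yl and 1,3-thiazol-4-yl have the same count of hetero atoms and of hydrogen-bond acceptors. The 1,3-thiazol-4-yl ring keeps only part of the drop seen with pyrazin-2-yl, with a 7.3-fold lower number from compound 1 to compound 3 (0.86 log units; beyond the scatter). Nothing available here explains the gap between these two rings. Where a pyridin-2-yl ring at this place would fall remains open, as does whether an amine on the pyrazin-2-yl ring would keep the number of compound 2 low.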